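A Double Bond Enters a Long Ether Chain

A few compounds are considered here, and "the series" means these few. Any claim that something is new, unique, unknown or untested is made for them only; others in the source may bear on it.

Both measured compounds share the same core, a resorcinol-like acetophenone carrying one long ether chain. Compound 1 `CCCCCCCCCCCCCCCCCCOc1cc(O)cc(O)c1C(C)=O` has a fully saturated chain. In a functional assay on A549 cells (Homo sapiens) for cytotoxicity, read by XTT assay, with a stated time of 72 h (on this read-out lower numbers stand for stronger inhibition and higher numbers for weaker inhibition), compound 1 gives > 100000 nM, which is a limit of the assay rather than a number; this is the limit of > 100000 nM in this assay, at which 1 of the 2 values shown sits. Compound 2 `CC(=O)c1c(O)cc(O)cc1OC/C=C(\C)CC/C=C(\C)CCC=C(C)C` carries a branched chain with several double bonds, and in this assay compound 2 gives 32000 nM. Within the data shown here, no step between compounds differing in one place has been measured, so the two values can only be read side by side: the unsaturated chain of compound 2 gives a number, the saturated chain of compound 1 does not.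

Compound 3 `CCCCCCCC/C=C\CCCCCCCCOc1cc(O)cc(O)c1C(C)=O` differs from compound 1 by dec-1-en-1-yl in place of decyl on a saturated chain carbon, eight bonds along the chain from an oxygen on an aromatic ring. The change adds one double bond outside aromatic rings and leaves everything else in place. The step from compound 1 to compound 3 is expected to be modest and toward stronger inhibition, an at least 2.0-fold lower number from compound 1 to compound 3 (0.30 log units; that floor lies within the scatter), because compound 2 with an unsaturated chain gives 32000 nM. Compound 3 is expected to give about 50000 nM, within a range of 15000 nM to 150000 nM.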

Compound 3, half-maximal inhibitory concentration: > 100000 nM
Compound 3 gave a limit, no number; the forecaster's own chance of this, stated with the estimate: 40%; at least 2.0-fold (0.30 log units) between middle value and limit.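

Among these compounds, compound 1 and compound 3 both stop at a limit of the assay rather than giving a number, so no step between them can be read: the limit of > 100000 nM in this assay, at which 2 of the 3 values shown sit. The compounds shown leave open whether dec-1-en-1-yl in place of decyl changes the result in this assay at all, and in which direction.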